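The compounds below may be only part of what the source reports. "The series", "measured", "known", "first", "only" and "open" are said of these compounds alone.

Within the data shown here, in a functional assay on U-937 cells (Homo sapiens) (on this read-out higher numbers stand for weaker inhibition and lower numbers for stronger inhibition), compound 1 (`COc1cc(C(=O)NS(=O)(=O)c2ccccc2C)ccc1Cc1c[nH]c2ccc(NC(=O)OC3CCCC3)cc12`) gives 2 nM as the highest of the three numbers measured so far. Compound 4 (`COc1cc(C(=O)NS(=O)(=O)c2ccccc2C)ccc1Cc1cn(C(=O)N2CCOCC2)c2ccc(NC(=O)OC3CCCC3)cc12`) differs from it by a single change ((morpholin-4-yl)carbonyl in place of hydrogen on an aromatic nitrogen) in which (morpholin-4-yl)carbonyl stands in place of hydrogen on an aromatic nitrogen. Two measured compounds carry a group on that same nitrogen. Compound 2 (`CCN(CC)C(=O)n1cc(Cc2ccc(C(=O)NS(=O)(=O)c3ccccc3C)cc2OC)c2cc(NC(=O)OC3CCCC3)ccc21`), with diethylcarbamoyl in place of the hydrogen, gives 0.8 nM and so shows a 2.5-fold lower number from compound 1 to compound 2 (0.40 log units; beyond the scatter) as a modest move toward stronger inhibition. Compound 3 (`COc1cc(C(=O)NS(=O)(=O)c2ccccc2C)ccc1Cc1cn(C(=O)N(c2ccccc2)c2ccccc2)c2ccc(NC(=O)OC3CCCC3)cc12`), with diphenylcarbamoyl there, gives 0.4 nM and its number also lies under that of compound 1. Neither of these two groups contains the ring of compound 4, so the precedent is only partial, and a modest move in the same direction is what can be expected. The step expected here is a 2.2-fold lower number from compound 1 to compound 4 (0.35 log units; beyond the scatter) toward stronger inhibition. Compound 4 is estimated at 0.9 nM with an expected range from 0.3 nM to 2.5 nM in this assay when it is measured.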

Compound 4, half-maximal inhibitory concentration: 2 nM
The estimate for compound 4 lay 2.2-fold (0.35 log units) below the measured number; the measured number falls inside the stated range.
By their numbers in this assay, from the lowest: compounds 3 and 2 (each within the scatter of the next); then compounds 1 and 4 (each within the scatter of the next).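

In this assay, placing (morpholin-4-yl)carbonyl on the aromatic nitrogen gives no change at the digits printed from compound 1 to compound 4 (within the scatter), so a carbonyl-linked group at this position does not always lower the number. What is attached to that carbonyl carbon makes a difference: with morpholin-4-yl in place of diethylamino, there is a 2.5-fold higher number from compound 2 to compound 4 (0.40 log units; beyond the scatter), so the lower number of compound 2 does not extend to compound 4. No measurement available here accounts for this difference between the two groups. The compounds shown leave open whether the ring as a whole or its oxygen atom goes with the higher number of compound 4, a question that piperidin-1-ylcarbonyl, with a carbon in place of that oxygen, could address. They also leave open how an acetyl group, with no nitrogen attached to its carbonyl, would behave on the same aromatic nitrogen.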